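Benzyl ether substitution on a diaryl ether amine series

A few compounds are considered here, and "the series" means these few. Any claim that something is new, unique, unknown or untested is made for them only; others in the source may bear on it.

Measured compounds:
compound 1 `COc1cccc(OC)c1OCCNCCOc1ccccc1OCc1ccccc1`: 26900 nM
compound 2 `COc1cccc(OC)c1OCCNCCOc1ccccc1OCc1ccccc1Cl`: 5400 nM

Within the data shown here, in a functional assay on PC-3 cells (Homo sapiens) for cytotoxicity, read by sulforhodamine B assay (a higher number here means a weaker inhibitor of growth, a lower number a stronger inhibitor of growth), compound 1 gives the higher of the two numbers so far; compound 2 sits at the lower one, and the step of a 5.0-fold lower number from compound 1 to compound 2 (0.70 log units; beyond the scatter) is the only measured change.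

Compound 3 `COc1cccc(OC)c1OCCNCCOc1ccccc1OCc1ccc(OC(C)C)cc1` differs from compound 1 by isopropoxy in place of hydrogen on an aromatic carbon. Among the measured compounds shown here, no measured step concerns this substituent or this place on the ring; the chloro step from compound 1 to compound 2 is the only guide, and it went in the direction of lower numbers. A smaller movement in the same direction is therefore expected, a 2.2-fold lower number from compound 1 to compound 3 (0.35 log units; beyond the scatter). Compound 3 is estimated at 12000 nM, with a range of 4000 nM to 35000 nM.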

Compound 3, concentration for 50% growth inhibition: 2000 nM
For compound 3 the middle estimate is 6.0-fold (0.78 log units) above the measured one; measured number outside the range, below it.
By their numbers in this assay, from the lowest: compound 3; then compound 2; then compound 1.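

In this assay the benzyl group takes a substituent well beyond chloro in size of effect: isopropoxy, para to a large group, gives a 13-fold lower number from compound 1 to compound 3 (1.13 log units; beyond the scatter) and this is a large step. The exchange of 2-chlorophenyl for 4-isopropoxyphenyl still gives a 2.7-fold lower number from compound 2 to compound 3 (0.43 log units; beyond the scatter) as a modest further gain, although substituent and place change together in that pair. No measured evidence bears on the reason for this gain.

Going by these compounds, whether the gain belongs to the isopropoxy group or to its place on the ring remains open. A methoxy group, a longer alkoxy chain or an amine at the same place would help separate these readings.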